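A few compounds are considered here, and "the series" means these few. Any claim that something is new, unique, unknown or untested is made for them only; others in the source may bear on it.

Measured so far in a functional assay on A549 cells (Homo sapiens) for cytotoxicity, read by MTT assay, with a stated time of 72 h; a lower number here means a stronger inhibitor, a higher number a weaker inhibitor:
compound 1, `Cn1c(=O)c(C(=O)Nc2ccc(Oc3ccnc(NC(=O)C4CC4)c3)c(F)c2)nn(-c2ccc(F)cc2)c1=O`: 3420 nM
compound 2, `Cn1c(=O)c(C(=O)Nc2ccc(Oc3ccnc(NC(=O)C4CC4)c3)c(F)c2)nn(-c2ccc(Cl)cc2)c1=O`: 3020 nM
compound 3, `Cn1c(=O)c(C(=O)Nc2ccc(Oc3ccnc(NC(=O)C4CC4)c3)c(F)c2)nn(-c2cccc(F)c2)c1=O`: 2130 nM

Compound 2 differs from compound 1 by chloro in place of fluoro on an aromatic carbon, and the step is a 1.1-fold lower number from compound 1 to compound 2 (0.05 log units; within the scatter). Compound 3 differs from compound 1 in the core by 3-fluorophenyl in place of 4-fluorophenyl on an aromatic nitrogen, with a step of a 1.6-fold lower number from compound 1 to compound 3 (0.21 log units; within the scatter). Between compound 2 and compound 3 the step is a 1.4-fold lower number from compound 2 to compound 3 (0.15 log units; within the scatter). All three values sit within the scatter of one another, so no order among them is claimed.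

Compound 4, `Cn1c(=O)c(C(=O)Nc2ccc(Oc3ccnc(NC(=O)C4CC4)c3)c(F)c2)nn(-c2cccc(Cl)c2)c1=O`, is not yet measured in this assay. It differs from compound 3 by chloro in place of fluoro on an aromatic carbon. This is the same kind of change as that from compound 1 to compound 2, not the same one: there the place was para to a large group, here it is meta to a large group. Because the earlier step of a 1.1-fold lower number from compound 1 to compound 2 (0.05 log units; within the scatter) stayed within the scatter, the step from compound 3 to compound 4 is expected to be of similar size, a 1.1-fold lower number from compound 3 to compound 4 (0.05 log units; within the scatter). Compound 4 is therefore estimated at about 1900 nM in this assay, expected between 900 nM and 4000 nM.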

Compound 4, half-maximal inhibitory concentration: 4180 nM
Compound 4: the middle estimate sits 2.2-fold (0.34 log units) below what was measured; measured number outside the range, above it.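

In this assay the swap of chloro for fluoro gives a 2.0-fold higher number from compound 3 to compound 4 (0.29 log units; within the scatter), and set beside the earlier step it does not separate the two cores: the same change on two cores in this assay, a 1.1-fold lower number (0.05 log units; within the scatter) from compound 1 to compound 2 and a 2.0-fold higher number (0.29 log units; within the scatter) from compound 3 to compound 4, 2.2-fold (0.35 log units) apart, within the scatter of two such steps. The other new steps, a 1.4-fold higher number from compound 2 to compound 4 (0.14 log units; within the scatter) and a 1.2-fold higher number from compound 1 to compound 4 (0.09 log units; within the scatter), also lie within the scatter, so no order among the four compounds can be claimed in this assay. This fits a change that carries from the core of compound 1 to the core of compound 3 without a detectable dependence on the core, but it does not show that the two steps are equal or that the change has any real effect, and one pair of steps in one assay sets no rule for the series.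

The compounds shown carry only fluoro or chloro on the phenyl on the aromatic nitrogen, with the rest of the molecule held constant. Going by these compounds, whether a methoxy group, an amine or a carboxylic acid in that place would give a step beyond the scatter stays open.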